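Swapping the methylamino group: expected tolerance of compound 4

The source may hold more compounds than are shown below. What is called first, only, known or untested is meant among the compounds shown, and "the series" means these compounds.

Of the compounds shown here, three built on a shared core have been tested in an ADME assay on Akata cells (Homo sapiens) for cytotoxicity, with a stated time of 7 days; a higher number here means that more compound is tolerated, a lower number that less compound is tolerated. Compound 1 `CNc1nc(N)nc2c1ncn2/C=C1/CC1(CO)CO` carries a methylamino group on an aromatic carbon of that core. In this assay compound 1 gives > 24000 nM, which is a limit of the assay and not a measured number. Compound 2 `Nc1nc(OCc2ccccc2)c2ncn(/C=C3/CC3(CO)CO)c2n1` carries benzyloxy in place of methylamino, and in this assay compound 2 gives > 20000 nM, again only a limit. Compound 3 `CC(C)Sc1nc(N)nc2c1ncn2/C=C1/CC1(CO)CO` carries isopropylsulfanyl in place of methylamino, and in this assay compound 3 gives > 20000 nM, also a limit. Because every value rests at the limit of > 20000 nM in this assay, at which 2 of the 3 values shown sit, or at the limit of > 24000 nM in this assay, at which 1 of the 3 values shown sits, the steps a step that the two limits leave unreadable from compound 1 to compound 2 and a step that the two limits leave unreadable from compound 1 to compound 3 cannot be sized, and the same holds for a step that the two limits leave unreadable from compound 2 to compound 3.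

Compound 4 `CCCOc1nc(N)nc2c1ncn2/C=C1/CC1(CO)CO` is the member not yet measured. It differs from compound 1 in one place: propoxy in place of methylamino on an aromatic carbon. Both measured steps that bear on this kind of exchange on the same aromatic carbon left tolerance beyond what the assay can read, so no step beyond the scatter is expected in this assay, in either direction. Compound 4 is therefore expected to give about 22000 nM, most likely reported once more as a limit rather than a number, within an expected range from 10000 nM to 50000 nM. The step of an at least 1.0-fold lower number from compound 1 to compound 4 (0.03 log units; that floor lies within the scatter) is estimated to lie within the usual scatter.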

Compound 4, half-maximal cytotoxic concentration: > 20000 nM
Compound 4 gave a limit, no number; the forecaster's own chance of this, stated with the estimate: 85%; the middle value is on the limit's open side.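

In this assay, for the compounds shown here, compound 4 gives > 20000 nM, which is a limit of the assay and not a number, so no step between it and compound 1, compound 2 or compound 3 can be read: the limit of > 20000 nM in this assay, at which 3 of the 4 values shown sit. The compounds shown leave open how much of each compound is actually tolerated, and whether exchanging this group changes tolerance at all.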